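The compounds below may be only part of what the source reports. "The series", "measured", "known", "first", "only" and "open" are said of these compounds alone.

Compound 1 `Nc1c(C(=O)NCc2ccc(F)cc2F)c(=O)n(O)c2ncc(CCc3ccccc3)cc12` and compound 2 `COC(=O)CCc1cnc2c(c1)c(N)c(C(=O)NCc1ccc(F)cc1F)c(=O)n2O` share a core and differ in one place, and both were tested in an ADME assay on HOS cells (Homo sapiens) for cytotoxicity, read by luminescence and ATP content, with a stated time of 48 h; a higher number here means that more compound is tolerated, a lower number that less compound is tolerated. In this assay compound 1 gives 18000 nM. Compound 2 gives > 250000 nM, which is a limit of the assay and not a number, so compound 2 stands at the limit of > 250000 nM in this assay, at which 1 of the 2 values shown sits.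

Compound 3 `COC(=O)CCc1cnc2c(c1)c(NCCO)c(C(=O)NCc1ccc(F)cc1F)c(=O)n2O` keeps the methoxycarbonyl chain of compound 2 and changes elsewhere: 2-hydroxyethyl in place of hydrogen on a nitrogen on an aromatic ring. For the measured compounds named here, the only measured step, an at least 13-fold higher number from compound 1 to compound 2 (1.14 log units; beyond the scatter), is large, but it replaces phenyl with methoxycarbonyl on the chain and does not touch this nitrogen. It shows that a single change can move compounds of this kind strongly in this assay, but it gives no direct size for the new change. Going by the values given here, no measured step involves 2-hydroxyethyl or the amino group. A small step is therefore expected, most likely toward a slightly lower number or none beyond the scatter, and another reading at the limit is quite possible. The expected change is an at least 1.2-fold lower number from compound 2 to compound 3 (0.09 log units; that floor lies within the scatter). For compound 3 the estimated value is 200000 nM, with an expected range from 70000 nM to 400000 nM.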

Compound 3, half-maximal cytotoxic concentration: > 250000 nM
Compound 3 was reported as a limit (the forecaster's own chance of this, stated with the estimate: 55%); middle value at least 1.2-fold (0.09 log units) from the limit.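

In this assay compound 3 gives > 250000 nM, which is a limit of the assay and not a number. Compound 2 also stands at a limit, so the step from compound 2 to compound 3 cannot be read: the limit of > 250000 nM in this assay, at which 2 of the 3 values shown sit. The compounds shown leave open whether 2-hydroxyethyl in place of hydrogen on a nitrogen on an aromatic ring changes the tolerated concentration at all.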